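Methyl for Methoxy on an Aromatic Carbon

A few compounds are considered here, and "the series" means these few. Any claim that something is new, unique, unknown or untested is made for them only; others in the source may bear on it.

In a functional assay on HepG2 cells (Homo sapiens) for inhibition, read by MTT assay, with a stated time of 24 h (a higher number here means a weaker inhibitor, a lower number a stronger inhibitor), compound 1 `CC1(C)[C@H]2CC[C@]1(C)N(Cc1cn(-c3ccccc3Br)nn1)C(=O)C2` gives 150 nM. Among the measured compounds shown here, compound 2 `COc1ccccc1-n1cc(CN2C(=O)C[C@@H]3CC[C@@]2(C)C3(C)C)nn1` gives 110 nM, and the two numbers lie within the scatter of each other, so compound 2 stands level with the only other measured compound. Compound 3 `Cc1ccccc1-n1cc(CN2C(=O)C[C@@H]3CC[C@@]2(C)C3(C)C)nn1` keeps the shared core and alters one group: methyl in place of methoxy on an aromatic carbon. The change sits on an aromatic carbon of a six-membered aromatic ring of carbon only, ortho to a large group. For the measured compounds named here, the one measured step that bears on this change sits on the same aromatic carbon, with methoxy in place of bromo: a 1.4-fold lower number from compound 1 to compound 2 (0.13 log units; within the scatter). Going by the values given here, no measured compound carries the methyl group, so the data hold no direct comparison for it. Among the compounds with values here, the single step at this carbon stayed within the scatter, and it offers only weak guidance, so no step beyond the scatter is expected in this assay and no firm direction can be given. For compound 3 the expected value is 120 nM, with an estimated range from 55 nM to 260 nM. This expected value amounts to a 1.1-fold higher number from compound 2 to compound 3 (0.04 log units; within the scatter).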

Compound 3, half-maximal inhibitory concentration: 150 nM
Compound 3: the middle estimate sits 1.3-fold (0.10 log units) below what was measured, within the range that was stated.
By their numbers in this assay, from the lowest: compounds 2, 1 and 3 (each within the scatter of the next).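

With methyl on this aromatic carbon, the position has now carried three groups, and in this assay methyl in place of methoxy gives (a 1.4-fold higher number from compound 2 to compound 3 (0.13 log units; within the scatter)) while methyl in place of bromo gives (no change at the digits printed from compound 1 to compound 3 (within the scatter)). The earlier compounds offered a single step at this carbon, whereas the three compounds now form a closed set of comparisons in which each group stands level with the other two, so this position, ortho to a large group, has shown no step beyond the scatter among bromo, methoxy and methyl. This holds even though methyl carries no hydrogen-bond acceptor and methoxy carries one, but nothing at hand accounts for why the three groups stand level.

As far as these compounds go, all three groups are small, so it remains open whether an amine, a carboxylic acid or a longer chain on this same carbon would stay level with them or give a step beyond the scatter. From the compounds shown here alone, it also remains open how methyl or methoxy would read on another carbon of this ring, since all three compounds carry their group in the one place.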